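A methylsulfanyl-for-hydrazino swap on a related core

The source may report more compounds than this note shows. Statements on the series, on what has been measured and on what is new or still open speak of the compounds shown alone.

Three compounds were measured in a functional assay, with a stated time of 10 min; a lower number here means a stronger inhibitor, a higher number a weaker inhibitor. Compound 1 `CN(C)c1ccc(-c2nc(NN)n(C)c(=O)c2C#N)cc1` gives 66 ug/mL in this assay. Compound 2 `Cn1c(NN)nc(-c2ccccc2Cl)c(C#N)c1=O` gives 46 ug/mL, and compound 3 `CSc1nc(-c2ccccc2Cl)c(C#N)c(=O)n1C` gives 67 ug/mL. The three values lie within the usual scatter of one another, so no order among them can be read from this assay. The difference between the core of compound 1 and the core of compound 2 is not broken down here.

From compound 2 to compound 3 one change was made: methylsulfanyl in place of aminoamino on an aromatic carbon. The step it produced was a 1.5-fold higher number from compound 2 to compound 3 (0.16 log units; within the scatter).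

Compound 4 `CSc1nc(-c2ccc(N(C)C)cc2)c(C#N)c(=O)n1C`, not yet measured, differs from compound 1 by the same kind of change: methylsulfanyl in place of aminoamino on an aromatic carbon. The surroundings differ only in that the place in compound 1 is meta to a group of 9 heavy atoms, where that in compound 2 is meta to a group of 7 heavy atoms.

Resting on the step from compound 2 to compound 3, a 1.5-fold higher number from compound 2 to compound 3 (0.16 log units; within the scatter), compound 4 is expected to give about 95 ug/mL in this assay, a step of a 1.4-fold higher number from compound 1 to compound 4 (0.16 log units; within the scatter), which would again stay within the scatter.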

Compound 4, half-maximal inhibitory concentration: 84 ug/mL
For compound 4 the middle estimate is 1.1-fold (0.05 log units) above the measured one; low and high end bracket the measured number.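

In this assay, putting methylsulfanyl in place of aminoamino on the core of compound 1 gives a 1.3-fold higher number from compound 1 to compound 4 (0.10 log units; within the scatter). Set beside the same change on the core of compound 2, the two steps cannot be told apart: the same change on two cores in this assay, a 1.5-fold higher number (0.16 log units; within the scatter) from compound 2 to compound 3 and a 1.3-fold higher number (0.10 log units; within the scatter) from compound 1 to compound 4, 1.1-fold (0.06 log units) apart, within the scatter of two such steps This shows only that the change left the number within the scatter on both cores, so the carry-over seen here is that of a step too small to read, and it shows neither a real effect of the swap nor that such agreement would hold on any further core.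

The compounds shown hold only aminoamino and methylsulfanyl on that aromatic carbon, so it stays open whether another group there, such as an amine, a carboxylic acid or a longer thioether chain, would move the number beyond the scatter. From the compounds shown here alone, it also stays open how the change would behave on a core carrying an aryl group other than those in these compounds.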